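Thiophen-2-yl for furan-2-yl on compound 2

The compounds below may be only part of what the source reports. "The series", "measured", "known", "first", "only" and "open" are said of these compounds alone.

Measured in a functional assay on HCT-116 cells (Homo sapiens) for inhibition, read by sulforhodamine B assay, with a stated time of 2 days; a higher number here means a weaker inhibitor of growth, a lower number a stronger inhibitor of growth:
- compound 1 `CC1=C(C(=O)Nc2ccc(C)cc2)C(c2ccc(O)cc2O)NC(NCc2ccccc2)=N1`: 66700 nM
- compound 2 `CC1=NN(C2=NC(C)=C(C(=O)Nc3cccc([N+](=O)[O-])c3)C(c3ccc(O)cc3O)N2)C(=O)/C1=C/c1ccco1`: > 100000 nM (a limit)

Compound 2 stands at the limit of > 100000 nM in this assay, at which 1 of the 2 values shown sits, so its > 100000 nM is a limit and not a number.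

Compound 3 `CC1=NN(C2=NC(C)=C(C(=O)Nc3cccc([N+](=O)[O-])c3)C(c3ccc(O)cc3O)N2)C(=O)/C1=C/c1cccs1` carries thiophen-2-yl in place of furan-2-yl on a double-bonded chain carbon bound to a double-bonded ring carbon. Going by the values given here, no measured step tests this exchange. In this assay no change beyond the scatter is expected, and the expected step is a number no higher from compound 2 to compound 3 (the limit leaves the size open). Compound 3 is estimated at 100000 nM, with an expected range of 50000 nM to 200000 nM.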

Compound 3, concentration for 50% growth inhibition: 26500 nM
Compound 3: middle estimate off by 3.8-fold (0.58 log units), on the high side; measured number below the stated range.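

In this assay, the place on a double-bonded chain carbon bound to a double-bonded ring carbon responds to a small exchange: thiophen-2-yl in place of furan-2-yl gives an at least 3.7-fold lower number from compound 2 to compound 3 (0.57 log units; beyond the scatter). The two groups match in heavy atoms and ring size, so sulfur for oxygen in the ring is the only difference. The value of compound 2 is a limit and not a number, which leaves the step open-ended: the limit of > 100000 nM in this assay, at which 1 of the 3 values shown sits.

From the compounds shown here alone, how a phenyl ring or a simple methyl group would read at this place remains open. So does whether the step holds once the nitro group on the amide ring is replaced.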